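Trading methoxy groups for a trifluoromethyl on the cinnamamide

The source may report more compounds than this note shows. Statements on the series, on what has been measured and on what is new or still open speak of the compounds shown alone.

Three compounds share one core and differ only in the aryl group at the end of the chain. Compound 1 `COc1ccc(C(=O)c2cc(OC)c(OC)c(OC)c2)cc1NC(=O)/C=C/c1cc(OC)c(OC)c(OC)c1` gives 2100 nM in a functional assay on ME-180 cells (Homo sapiens) for cytotoxicity, read by MTT assay, with a stated time of 72 h; a lower number here means a stronger inhibitor, a higher number a weaker inhibitor. Compound 2 `COc1ccc(C(=O)c2cc(OC)c(OC)c(OC)c2)cc1NC(=O)/C=C/c1ccc(OC)c(OC)c1` gives 8900 nM in this assay, and compound 3 `COc1ccc(/C=C/C(=O)Nc2cc(C(=O)c3cc(OC)c(OC)c(OC)c3)ccc2OC)cc1` gives 11800 nM. Among these three numbers compound 2 stands second highest: its nearest neighbour is compound 3, within the scatter, while compound 1 lies furthest away, with a 4.2-fold higher number from compound 1 to compound 2 (0.63 log units; beyond the scatter) as the step between them.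

Compound 4 `COc1ccc(C(=O)c2cc(OC)c(OC)c(OC)c2)cc1NC(=O)/C=C/c1ccc(C(F)(F)F)cc1` carries the change (4-(trifluoromethyl)phenyl in place of 3,4-dimethoxyphenyl on a double-bonded chain carbon bound to a double-bonded chain carbon). Going by the values given here, two measured steps bear on it. Removing one methoxy gave a 4.2-fold higher number from compound 1 to compound 2 (0.63 log units; beyond the scatter), and removing a second gave a 1.3-fold higher number from compound 2 to compound 3 (0.12 log units; within the scatter), so losing methoxy groups has been tied to weaker inhibition or no clear change. Compound 4 loses both methoxy groups and gains a trifluoromethyl, for which no step is shown. Compound 4 is therefore expected to land near or somewhat above compound 3, an estimated 1.7-fold higher number from compound 2 to compound 4 (0.23 log units; within the scatter), giving 15000 nM with a range from 5000 nM to 50000 nM.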

Compound 4, half-maximal inhibitory concentration: 800 nM
Beside the measured number, compound 4's estimate is 19-fold (1.27 log units) above it; the whole stated range lies above it.
By their numbers in this assay, from the lowest: compound 4; then compound 1; then compounds 2 and 3 (each within the scatter of the next).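

Until now, losing methoxy groups from this aryl group had gone only with weaker inhibition or no clear change, but with a trifluoromethyl the direction in this assay reverses: there is an 11-fold lower number from compound 2 to compound 4 (1.05 log units; beyond the scatter) and also a 15-fold lower number from compound 3 to compound 4 (1.17 log units; beyond the scatter), both large steps. The 4-(trifluoromethyl)phenyl group also outdoes the 3,4,5-trimethoxyphenyl group, with a 2.6-fold lower number from compound 1 to compound 4 (0.42 log units; beyond the scatter), so methoxy groups are not needed here for the lowest number of the series. Nothing available accounts for this gain.

Still open, from the compounds shown here alone, is whether the gain belongs to the trifluoromethyl itself or would also come with a chlorine atom or a nitrile in its place. Also open, going by these compounds, is whether an amine or a carboxylic acid on this aryl group would keep the number as low.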